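Carboxy for Amino on the Phenyl of Compound 2

The source may report more compounds than this note shows. Statements on the series, on what has been measured and on what is new or still open speak of the compounds shown alone.

Within the data shown here, compound 2 `Nc1ccc(-c2cnc(C(=O)CCCCCCc3ccccc3)o2)cc1` gives 90 nM in an assay (Rattus norvegicus) for inhibition of Fatty-acid amide hydrolase 1 (Homo sapiens) (a lower number here means a stronger inhibitor, a higher number a weaker inhibitor), the higher of the two numbers known here; compound 1 `NC(=O)c1cccc(-c2cnc(C(=O)CCCCCCc3ccccc3)o2)c1` gives 6 nM in this assay. Compound 3 `O=C(O)c1ccc(-c2cnc(C(=O)CCCCCCc3ccccc3)o2)cc1` carries carboxy in place of amino on an aromatic carbon. Among the measured compounds shown here, the only measured step, a 15-fold higher number from compound 1 to compound 2 (1.18 log units; beyond the scatter), also alters the group on this phenyl, so a shift of similar size is plausible in either direction. Compound 3 is expected to land near compound 2, with a modest step of a 1.7-fold higher number from compound 2 to compound 3 (0.22 log units; within the scatter). The estimate for compound 3 is 150 nM, ranging from 30 nM to 800 nM.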

Compound 3, inhibition constant: 60 nM
Compound 3: middle estimate off by 2.5-fold (0.40 log units), on the high side, and the stated range covers the measured number.
By their numbers in this assay, from the lowest: compound 1; then compounds 3 and 2 (each within the scatter of the next).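

In this assay, the change from 4-aminophenyl to 4-carboxyphenyl gives a 1.5-fold lower number from compound 2 to compound 3 (0.18 log units; within the scatter), so these two groups cannot be told apart at this position. The 3-carbamoylphenyl group still stands apart, with a 10-fold higher number from compound 1 to compound 3 (1.00 log units; beyond the scatter), and the earlier gap therefore holds against a second group on the phenyl. Nothing available here explains either step. Going by these compounds, whether that gap follows the carbamoyl group itself or its place on the phenyl stays open, and a 4-carbamoylphenyl or a 3-carboxyphenyl group would separate the two.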